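Swapping One Ring on Compound 2

A few compounds are considered here, and "the series" means these few. Any claim that something is new, unique, unknown or untested is made for them only; others in the source may bear on it.

Measured so far in an in vivo ADME assay on the whole organism for pharmacokinetics, with Canis familiaris (Canis lupus familiaris) as the target, at a dose of 1 mg/kg (on this read-out lower numbers stand for narrower distribution and higher numbers for wider distribution into tissues), are two compounds.
Compound 1 `CC(C)(O)c1ccn2c(-c3ccc(F)c(-c4cccnc4)c3)cnc2n1` gives 0.6 L/kg here.
Compound 2 `CC(C)(O)c1cnn2c(-c3ccc(F)c(-c4ncc(F)cc4F)c3)cnc2n1` gives 2.3 L/kg here.

Of these two, compound 2 has the higher number, and compound 1 lies below it by more than the usual scatter. The two differ in more than one place, so their gap cannot be tied to any single change.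

Compound 3 `CC(C)(O)c1cnn2c(-c3ccc(F)c(-c4ncccc4C#N)c3)cnc2n1` differs from compound 2 in one place, where 3-cyanopyridin-2-yl stands in place of 3,5-difluoropyridin-2-yl on an aromatic carbon (3-cyanopyridin-2-yl in place of 3,5-difluoropyridin-2-yl on an aromatic carbon). For the measured compounds named here, no measured pair shows this swap alone, so the expectation is loose. It rests only on the span of these two values in this assay. A small fall is expected, one that would stay within the scatter (a 1.4-fold lower number from compound 2 to compound 3 (0.16 log units; within the scatter)). For compound 3 the estimated value is 1.6 L/kg (expected range 0.7 L/kg to 3.4 L/kg).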

Compound 3, volume of distribution at steady state: 1.5 L/kg
For compound 3 the middle estimate is 1.1-fold (0.03 log units) above the measured one; measured number inside the range.
By their numbers in this assay, from the lowest: compound 1; then compounds 3 and 2 (each within the scatter of the next).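

For the compounds shown here, this is the first comparison in the set that changes only one place. In this assay, putting 3-cyanopyridin-2-yl in place of 3,5-difluoropyridin-2-yl on an aromatic carbon gives a 1.5-fold lower number from compound 2 to compound 3 (0.19 log units; within the scatter), so on this read-out the two groups cannot be told apart. At this position, ortho to a fluoro group, fluorine atoms on the pyridine ring can therefore give way to a nitrile without a clear shift in the number, though no measurement here says why.

Still open, as far as these compounds go, is whether a quite different group in this place, such as an amine or a carboxylic acid, would move the number beyond the scatter. Also open, from the compounds shown here alone, is how much of the gap between compound 1 and compound 2 belongs to this ring and how much to the core.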